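The compounds below may be only part of what the source reports. "The series", "measured", "known", "first", "only" and "open" are said of these compounds alone.

Measured so far:

- compound 1, `CC(=O)N1CC2CC(C1)N2`: 750 nM
- compound 2, `CCCC(=O)N1CC2CC(C1)N2`: 300 nM
- compound 3, `O=C([C@@H]1C[C@@H]1F)N1CC2CC(C1)N2`: 88 nM

In an assay on CHO cells for agonist activity at Neuronal acetylcholine receptor; alpha3/alpha6/beta2/beta3 (Homo sapiens), read by FLIPR and calcium flux (a higher number here means that more compound is needed for the effect, a lower number that less compound is needed), compound 1 gives 750 nM, the highest number of the three, meaning the most compound is needed for the effect. The step to the nearest compound was a 2.5-fold lower number from compound 1 to compound 2 (0.40 log units; beyond the scatter), and the step to the furthest was an 8.5-fold lower number from compound 1 to compound 3 (0.93 log units; beyond the scatter).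

Compound 4, `C[C@@H]1C[C@@H]1C(=O)N1CC2CC(C1)N2`, has not yet been measured. It differs from compound 1 in one place: a group of 4 heavy atoms (4 carbon; one three-membered non-aromatic ring of carbon only) in place of one carbon atom, on a carbonyl carbon

Within the data shown here, two measured steps bear on this change. Both enlarge the group on the carbonyl carbon of compound 1, and both lowered the number: a 2.5-fold lower number from compound 1 to compound 2 (0.40 log units; beyond the scatter) and an 8.5-fold lower number from compound 1 to compound 3 (0.93 log units; beyond the scatter). Among the measured compounds shown here, the three-membered ring in compound 4 resembles the one in compound 3 most closely, differing only in the methyl in place of the fluorine, and the step of a 3.4-fold lower number from compound 2 to compound 3 (0.53 log units; beyond the scatter) shows the ring gave a lower number than a plain chain. A lowering beyond the scatter is therefore expected in this assay for compound 4, estimated as a 6.3-fold lower number from compound 1 to compound 4 (0.80 log units; beyond the scatter), giving an expected value of 120 nM with a range from 40 nM to 350 nM.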

Compound 4, half-maximal effective concentration: 920 nM
The estimate for compound 4 lay 7.7-fold (0.88 log units) below the measured number; measured number above the stated range.
By their numbers in this assay, from the lowest: compound 3; then compound 2; then compounds 1 and 4 (each within the scatter of the next).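

In this assay, a three-membered ring on the carbonyl carbon does not lower the number by itself: replacing the methyl with the methyl-bearing ring gives a 1.2-fold higher number from compound 1 to compound 4 (0.09 log units; within the scatter), so the two compounds cannot be told apart. Against the propyl chain, this ring goes the opposite way from the fluorine-bearing ring, with a 3.1-fold higher number from compound 2 to compound 4 (0.49 log units; beyond the scatter). Exchanging only fluorine for methyl on the ring gives a 10-fold higher number from compound 3 to compound 4 (1.02 log units; beyond the scatter), so the low number of compound 3 goes with the fluorine-bearing ring, not with the ring as such.

As far as these compounds go, it remains open whether a bare cyclopropyl or a ring bearing a hydroxyl group would sit closer to compound 3 or to compound 4. Nothing measured here explains why fluorine and methyl on this ring differ so strongly.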